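A few compounds are considered here, and "the series" means these few. Any claim that something is new, unique, unknown or untested is made for them only; others in the source may bear on it.

Measured in a functional assay on the whole organism with Mus musculus as the target; a higher number here means that more compound is needed for the effect, a lower number that less compound is needed:
- Compound 1 `CN(C)C(=O)Cn1c(-c2cccc(Cl)c2)nc2cccnc21`: > 56.2 mg/kg; < 100 mg/kg (2 entries)
- Compound 2 `Cc1ccc(-c2nc3cccnc3n2CC(=O)N(C)C)cc1`: 4.7 mg/kg

Compound 1 gives > 56.2 mg/kg; < 100 mg/kg (2 entries), which is a limit of the assay and not a number. Within the data shown here, compound 2, at 4.7 mg/kg, therefore holds the only single number in this assay.

Compound 3 `CN(C)C(=O)Cn1c(-c2ccco2)nc2cccnc21` has furan-2-yl in place of the 4-methylphenyl of compound 2, on an aromatic carbon of the five-membered aromatic ring with 2 nitrogen (furan-2-yl in place of 4-methylphenyl on an aromatic carbon). Among the measured compounds shown here, no step between measured compounds is available, so the size of this change can only be judged loosely. Starting from compound 2 at 4.7 mg/kg, a moderate move beyond the scatter is expected, towards more compound being needed, and the estimate is a 3.8-fold higher number from compound 2 to compound 3 (0.58 log units; beyond the scatter). Compound 3 is expected at 18 mg/kg, within an estimated range of 6 mg/kg to 60 mg/kg.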

Compound 3, dose for half-maximal effect: > 100 mg/kg
Compound 3: no number, only a limit; the forecaster's own chance of this, stated with the estimate: 25%; at least 5.5-fold (0.74 log units) between middle value and limit.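

In this assay, furan-2-yl in place of 4-methylphenyl on an aromatic carbon of the five-membered aromatic ring gives an at least 21-fold higher number from compound 2 to compound 3 (1.32 log units; beyond the scatter), a large step. Compound 3 gives > 100 mg/kg, which is a limit of the assay and not a number. Among these compounds, this is the first step that can be read at this position, and it shows that exchanging this one ring for another is enough to carry the read-out from a single number to a limit, which compounds 1 and 2, with no step between them, could not show.

How large the step really is stays open: the limit of > 100 mg/kg in this assay, at which 1 of the 3 values shown sits. The compounds shown also do not separate the effect of the ring oxygen from that of the lost methyl, and they leave open how an unsubstituted phenyl or a thiophen-2-yl group would behave on this carbon.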